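This account rests on a few compounds, and the source may have more. Where it says the series, first, only, none or still open, it means among the compounds named here.

Measured compounds:
compound 1, `O=C(Nc1ccc(Oc2ccnc3[nH]ccc23)cc1)c1nn(-c2ccc(Br)cc2)ccc1=O`, 4280 nM
compound 2, `O=C(Nc1ccc(Oc2ccnc3[nH]ccc23)cc1)c1nn(-c2ccccc2)ccc1=O`, 17800 nM
compound 3, `Cn1ccc2c(Oc3ccc(NC(=O)c4nn(-c5ccc(Br)cc5)ccc4=O)cc3F)ccnc21`, the limit of > 60000 nM in this assay, at which 1 of the 3 values shown sits.

In a functional assay on HepG2 cells (Homo sapiens) for cytotoxicity, read by MTT assay, with a stated time of 72 h (a higher number here means a weaker inhibitor, a lower number a stronger inhibitor), compound 1 gives 4280 nM. The change hydrogen in place of bromo on an aromatic carbon brings a 4.2-fold higher number from compound 1 to compound 2 (0.62 log units; beyond the scatter), so in this assay compound 2 gives 17800 nM. Compound 3 carries a different core; how the two cores differ is not broken down here. In this assay compound 3 reaches only the limit of the measurement, > 60000 nM, and no number is known.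

Compound 4, `Cn1ccc2c(Oc3ccc(NC(=O)c4nn(-c5ccccc5)ccc4=O)cc3F)ccnc21`, has not yet been tested. It differs from compound 3 by hydrogen in place of bromo on an aromatic carbon, the same change as from compound 1 to compound 2. On that earlier step, a 4.2-fold higher number from compound 1 to compound 2 (0.62 log units; beyond the scatter), a weaker inhibitor than compound 3 is expected, so compound 4 is expected to remain at the limit, with a step that the limit leaves unreadable from compound 3 to compound 4. For compound 4 the estimate in this assay is 200000 nM, between 60000 nM and 700000 nM.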

Compound 4, half-maximal inhibitory concentration: > 60000 nM
Compound 4 gave a limit, no number (the forecaster's own chance of this, stated with the estimate: 90%); the middle value lies beyond the limit too.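

Compound 3 and compound 4 both give only a limit and no number, so no step between them can be read: the limit of > 60000 nM in this assay, at which 2 of the 4 values shown sit.

As far as these compounds go, whether going from 4-bromophenyl to phenyl changes the number on the core of compound 3 as it does on the core of compound 1 stays open.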